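A few compounds are considered here, and "the series" means these few. Any claim that something is new, unique, unknown or untested is made for them only; others in the source may bear on it.

Measured compounds:
- Compound 1, `CCCC(Oc1ccc(-n2cc(C(=O)N(C)C)cn2)cc1)c1ccc(C(=O)NCCC(=O)O)cc1`: 0.5
- Compound 2, `O=C(O)CCNC(=O)c1ccc(C(Oc2ccc(-n3cc(C(F)(F)F)cn3)cc2)C2CCCC2)cc1`: 3.3

The account turns on the shared core of compound 1 and the group carried on the five-membered aromatic ring with two nitrogens. In a physicochemical assay for lipophilicity, using the shake flask method, at pH 7.4 (on this read-out higher numbers stand for higher lipophilicity and lower numbers for lower lipophilicity), compound 1 gives 0.5, the lowest of the two numbers recorded. Its nearest neighbour, compound 2, gives in this assay a value of 3.3, a gap that lies beyond the scatter; the two differ in several places at once, so only their two values are compared here.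

Compound 3, `CCCC(Oc1ccc(-n2cc(C)cn2)cc1)c1ccc(C(=O)NCCC(=O)O)cc1`, has not yet been measured in this assay. It departs from compound 1 in one place: methyl in place of dimethylcarbamoyl on an aromatic carbon. Dimethylcarbamoyl leaves and methyl enters on the aromatic carbon of the five-membered ring, two ring bonds from the ring nitrogen. Among the compounds with values here, no measured pair shows this exact change, so the expectation rests on the counted difference alone.

For compound 3 the estimated step is a number 1.40 log units higher from compound 1 to compound 3 (beyond the scatter), expected upward and beyond the scatter. Compound 3 is therefore estimated at 1.9, with a range from 1.3 to 2.6.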

Compound 3, distribution coefficient: 2.1
For compound 3 the middle estimate is 0.20 log units below the measured one; the range from low to high includes it.
By their numbers in this assay, from the lowest: compound 1; then compound 3; then compound 2.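

In this assay, the exchange of dimethylcarbamoyl for methyl on an aromatic carbon of the five-membered aromatic ring with 2 nitrogen, two ring bonds from the ring nitrogen, gives a number 1.60 log units higher from compound 1 to compound 3 (beyond the scatter) and is the first change in one place among the compounds shown. This large step shows that this single exchange, with the rest of the core of compound 1 held fixed, is enough to move the number beyond the scatter, which the gap to compound 2, spread over several places, could not show. Nothing measured here accounts for the size of the step.

On these data alone, what stays open is how the read-out responds to other groups on this same aromatic carbon, such as a nitrile, an unsubstituted carboxamide, an amine or a longer chain like ethyl, and so whether the values follow any order across such groups. As far as these compounds go, it is also open whether the exchange of dimethylcarbamoyl for methyl would give a step of similar size on a core other than that of compound 1.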